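Methoxy removal on the pyrimidine aryl: expected effect in compound 4

This account rests on a few compounds, and the source may have more. Where it says the series, first, only, none or still open, it means among the compounds named here.

Three measured members share one core. Compound 1 `COc1ccc(-c2nc(SCC(=O)c3sc(-c4ccccc4)nc3C)nc(N)c2C#N)cc1` gives 33.8% in a functional assay on U-87MG ATCC cells for antiproliferative activity against U-87 MG (Homo sapiens), read by MTT assay, with a stated time of 48 h, tested at 50 uM; a higher number here means a weaker effect of the compound at the concentration tested, a lower number a stronger effect. Compound 2 `COc1ccc(-c2nc(C)c(C(=O)CSc3nc(N)c(C#N)c(-c4ccc(OC)cc4)n3)s2)cc1` gives 13% in this assay, and compound 3 `COc1ccc(-c2nc(SCC(=O)c3sc(-c4ccc(Cl)cc4)nc3C)nc(N)c2C#N)cc1` gives 17.8% in this assay. Between the measured pairs, a number 20.8 percentage points higher from compound 2 to compound 1 (beyond the scatter), a number 16 percentage points lower from compound 1 to compound 3 (beyond the scatter), and a number 4.8 percentage points higher from compound 2 to compound 3 (within the scatter).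

Compound 4 `Cc1nc(-c2ccc(Cl)cc2)sc1C(=O)CSc1nc(N)c(C#N)c(-c2ccccc2)n1` is not yet measured. It differs from compound 3 by hydrogen in place of methoxy on an aromatic carbon. The same change carries compound 2 to compound 1, where it differs as hydrogen in place of methoxy on an aromatic carbon and made the step of a number 20.8 percentage points higher from compound 2 to compound 1 (beyond the scatter). The two cores differ as chloro in place of methoxy on an aromatic carbon; the place of the change is the same in both pairs, so it is the same change.

Because a number 20.8 percentage points higher from compound 2 to compound 1 (beyond the scatter) was a modest rise beyond the scatter, a step of similar direction and size is expected here, namely a number 18.2 percentage points higher from compound 3 to compound 4 (beyond the scatter), resting on that single earlier pair. Compound 4 is therefore estimated to give 36% in this assay, with a range from 22% to 50%.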

Compound 4, a percentage reported as activity, at one concentration (the size of the read-out at that concentration, not a potency): 15.2%
The estimate for compound 4 lay 20.8 percentage points above the measured number; the measured number lies below the stated range.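

The change from 4-methoxyphenyl to phenyl, applied to the chloro-bearing core of compound 3, gives a number 2.6 percentage points lower from compound 3 to compound 4 (within the scatter) in this assay. The same change therefore does not transfer between the two cores, and its result in this series depends on whether the other aryl group carries methoxy, hydrogen or chloro, so the step seen on one core is a poor guide to the step on the other: the same change on two cores in this assay, a number 20.8 percentage points higher (beyond the scatter) from compound 2 to compound 1 and a number 2.6 percentage points lower (within the scatter) from compound 3 to compound 4, 23.4 percentage points apart, beyond the scatter of two such steps

This shows an interaction between the two places within these four compounds only; it rests on one pair per core at a single concentration, gives no potency, and does not show why the two steps differ.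

As far as these compounds go, whether the change keeps its larger step on the methoxy-bearing core alone, or also with other groups in the place of chloro, such as a fluoro, an amine or a carboxylic acid, stays open. Also open, from the compounds shown here alone, is how these steps would look across a range of concentrations rather than at one.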